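The source may report more compounds than this note shows. Statements on the series, on what has been measured and on what is new or still open speak of the compounds shown alone.

Measured in a functional assay on MCF7 cells (Homo sapiens) for antiproliferative activity; a lower number here means a stronger inhibitor, a higher number a weaker inhibitor:
- compound 1 `CCCNCCCOc1ccc2cc(NC(=O)c3ccc(O)c(CC=C(C)C)c3)c(=O)oc2c1C` gives 980 nM
- compound 2 `CCCN(CCC)CCCOc1ccc2cc(NC(=O)c3ccc(O)c(CC=C(C)C)c3)c(=O)oc2c1C` gives > 50000 nM (a limit, not a number)

Compound 2 stands at the limit of > 50000 nM in this assay, at which 1 of the 2 values shown sits. Compound 3 `CC(C)=CCc1cc(C(=O)Nc2cc3ccc(OCCCN(C)C(C)(C)C)c(C)c3oc2=O)ccc1O` differs from compound 2 by methyl(tert-butyl)amino in place of dipropylamino on a saturated chain carbon, three bonds along the chain from an oxygen on an aromatic ring. Within the data shown here, the only measured step bearing on this is an at least 51-fold higher number from compound 1 to compound 2 (1.70 log units; beyond the scatter), a large one, with propyl in place of hydrogen on an amine nitrogen. Compound 3 also has no hydrogen on that nitrogen, so it is expected to stay weak in this assay, with a modest move to a lower number or none measurable. The expected change is an at least 3.3-fold lower number from compound 2 to compound 3 (0.52 log units; beyond the scatter). Compound 3 is estimated at 15000 nM, within a range of 2000 nM to 50000 nM.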

Compound 3, half-maximal inhibitory concentration: 1140 nM
Compound 3: the middle estimate sits 13-fold (1.12 log units) above what was measured; measured number outside the range, below it.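

In this assay, a hydrogen on the amine nitrogen proves not to be required: compound 3 has none, yet the step is a 1.2-fold higher number from compound 1 to compound 3 (0.07 log units; within the scatter). The value of compound 2 is a limit, not a number: the limit of > 50000 nM in this assay, at which 1 of the 3 values shown sits. Exchanging dipropylamino for methyl(tert-butyl)amino gives an at least 43-fold lower number from compound 2 to compound 3 (1.64 log units; beyond the scatter), so at this position the loss follows the particular groups on the nitrogen, not simply the absence of that hydrogen.

Going by these compounds, what in dipropylamino carries the loss stays open; dimethylamino, diethylamino or a piperidine at this position would bear on it.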